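The source may hold more compounds than are shown below. What is called first, only, known or untested is meant among the compounds shown, and "the series" means these compounds.

In a functional assay on MCF7 cells (Homo sapiens) for antiproliferative activity, read by MTT assay, with a stated time of 48 h (on this read-out higher numbers stand for weaker inhibition and lower numbers for stronger inhibition), compound 1 `COc1ccc2[nH]c(-c3cn(-c4ccccc4)nc3-c3ccccc3)nc2c1` gives 1590 nM and compound 2 `Clc1ccc(-c2nn(-c3ccccc3)cc2-c2nc3cc(Br)ccc3[nH]2)cc1` gives 1920 nM. Within the data shown here, these two values lie within the usual scatter of each other, so compound 2 stands level with the only other measured compound. Compound 3 `COc1ccc2[nH]c(-c3cn(-c4ccccc4)nc3-c3ccc(Cl)cc3)nc2c1` has not yet been measured. It differs from compound 2 in one place, with methoxy in place of bromo on an aromatic carbon of the fused two-ring system (methoxy in place of bromo on an aromatic carbon). Among the measured compounds shown here, no measured pair shows this exchange alone, so the data offer no direct step to go by. For the measured compounds named here, with only two close values available, no change beyond the scatter is expected in this assay, and no direction is favoured. The expected change is a 1.1-fold lower number from compound 2 to compound 3 (0.05 log units; within the scatter). For compound 3 the estimated value is 1700 nM, with an expected range from 650 nM to 4500 nM.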

Compound 3, half-maximal inhibitory concentration: 1760 nM
Compound 3: middle estimate off by 1.0-fold (0.02 log units), on the low side; the range from low to high includes it.
By their numbers in this assay, from the lowest: compounds 1, 3 and 2 (each within the scatter of the next).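

In this assay, methoxy in place of bromo on this aromatic carbon of the fused two-ring system gives a 1.1-fold lower number from compound 2 to compound 3 (0.04 log units; within the scatter) with the chloro group held in place, so the two groups stand level at this position. Chloro in place of hydrogen on an aromatic carbon, with methoxy held in place, gives a 1.1-fold higher number from compound 1 to compound 3 (0.04 log units; within the scatter) and likewise leaves the compounds level. No measurement at hand bears on why neither exchange moves the number beyond the scatter.

The three compounds leave open whether an amine, a carboxylic acid or a longer chain on this aromatic carbon would stay level with bromo and methoxy or move away from them. They also leave open whether chloro in place of hydrogen would stay as flat with bromo on the fused two-ring system.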